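The compounds below may be only part of what the source reports. "The series", "measured", "known", "first", "only" and "open" are said of these compounds alone.

Compound 1 `O=C(NOCc1ccccc1F)c1cn(-c2ccccc2)nc1-c1ccccc1` and compound 2 `O=C(NOCc1ccccc1Cl)c1cn(-c2ccccc2)nc1-c1ccccc1` share one core and differ only in the halogen on the benzyl ring. In an ADME assay on HEK-293T cells (Homo sapiens) for antiproliferative activity, read by MTT assay, with a stated time of 48 h, in the presence of a further agent that is not named here (a lower number here means that less compound is tolerated, a higher number that more compound is tolerated), compound 1 gives 75700 nM, and compound 2 gives 82100 nM; the step of a 1.1-fold higher number from compound 1 to compound 2 (0.04 log units; within the scatter) tells that exchanging the halogen made no difference that the measurement can resolve. Compound 2 therefore stands with the higher of the two numbers, but its nearest neighbour, compound 1, lies within the scatter of it, so no order between the two can be claimed.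

Compound 3 `O=C(NOCc1ccc(Cl)cc1Cl)c1cn(-c2ccccc2)nc1-c1ccccc1` carries the change (chloro in place of hydrogen on an aromatic carbon). For the measured compounds named here, the only step available, a 1.1-fold higher number from compound 1 to compound 2 (0.04 log units; within the scatter), concerns a different halogen exchange at the same ring and was within the scatter; there is no measured step in which a second chloro is added, so the bearing of that step is indirect. On this basis compound 3 is expected to show a step of a 1.3-fold lower number from compound 2 to compound 3 (0.10 log units; within the scatter) in this assay, not beyond the scatter, and its value is estimated at 65000 nM, with a range from 28000 nM to 150000 nM.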

Compound 3, half-maximal cytotoxic concentration: 40200 nM
Compound 3: middle estimate off by 1.6-fold (0.21 log units), on the high side; measured number inside the range.
By their numbers in this assay, from the lowest: compounds 3, 1 and 2 (each within the scatter of the next, the first and the last beyond it).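

Of the steps shown, the addition of a chloro para to a large group and meta to a chloro group, which turns 2-chlorobenzyl into 2,4-dichlorobenzyl, is the only one in this assay that passes the scatter, with a 2.0-fold lower number from compound 2 to compound 3 (0.31 log units; beyond the scatter) as a modest step, whereas the halogen exchange gave only a 1.1-fold higher number from compound 1 to compound 2 (0.04 log units; within the scatter) and could not be resolved. This place on the benzyl ring can therefore move the number towards less compound tolerated, but only just, since the comparison with the fluoro compound gives a 1.9-fold lower number from compound 1 to compound 3 (0.27 log units; within the scatter) and stays within the scatter, so the result holds against compound 2 and not against compound 1. Nothing at hand offers an explanation for the step.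

Going by these compounds, whether a chloro at this place would give a similar step on a benzyl ring that carries no other halogen remains open, as does whether the second chloro is needed for the step at all. Also open, on these data alone, is how a methoxy group, an amine or a carboxylic acid at the same place would read in this assay and whether any of them would move the number further.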